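Thromboxane receptor antagonists: chain oxygen in the acid side chain

The source may hold more compounds than are shown below. What is called first, only, known or untested is meant among the compounds shown, and "the series" means these compounds.

Measured so far:
compound 1 `O=C(O)CC/C=C1\C[C@H]2C[C@@H](O)[C@H](/C=N/NC(=O)Nc3cccc(Cl)c3)[C@H]2C1`, 5200 nM
compound 2 `O=C(O)COC/C=C1/C[C@H]2C[C@@H](O)[C@H](/C=N/NC(=O)Nc3cccc(Cl)c3)[C@H]2C1`, 180 nM

In a functional assay on a cell-free system (plasma) for agonist activity at thromboxane A2 receptor (Homo sapiens) (a higher number here means a weaker inhibitor, a lower number a stronger inhibitor), compound 2 gives 180 nM, the lowest number of the two measured. Compound 1 gives 5200 nM in this assay, a gap beyond the scatter, but compound 1 and compound 2 differ in more than one place, so that gap cannot be tied to the side chain alone.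

Compound 3 `O=C(O)CC/C=C1/C[C@H]2C[C@@H](O)[C@H](/C=N/NC(=O)Nc3cccc(Cl)c3)[C@H]2C1` is not yet measured. The change from compound 2 to compound 3 is carboxymethyl in place of carboxymethoxy on a saturated chain carbon bound to a double-bonded chain carbon, with the shared core and the semicarbazone arm left as they are. Among the compounds with values here, no measured pair covers this change by itself. The expectation is a moderate step toward a higher number from compound 2 to compound 3, a 3.3-fold higher number from compound 2 to compound 3 (0.52 log units; beyond the scatter), with wide uncertainty. Compound 3 is estimated at 600 nM in this assay, with a range from 150 nM to 2500 nM.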

Compound 3, half-maximal inhibitory concentration: 600 nM
Compound 3: the middle estimate sits on the measured number at the digits printed; the range from low to high includes it.
By their numbers in this assay, from the lowest: compound 2; then compound 3; then compound 1.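

With compound 3, two single changes can be read separately in this assay. Carboxymethyl in place of carboxymethoxy on a saturated chain carbon bound to a double-bonded chain carbon gives a 3.3-fold higher number from compound 2 to compound 3 (0.52 log units; beyond the scatter), so the chain oxygen changes the number beyond the scatter when the double bond is held as drawn in both compounds. The other step, an 8.7-fold lower number from compound 1 to compound 3 (0.94 log units; beyond the scatter), belongs to the double-bond configuration alone, because nothing else separates the pair: the fact that compounds 1 and 3 differ only in the configuration as drawn

It remains open whether the double-bond configuration has a comparable effect when carboxymethoxy is in the chain, as the compounds shown read that step only with carboxymethyl. Also open, going by these compounds, is how a longer chain ending in a carboxylic acid, or an amide in place of that acid, would compare at this position.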